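Dropping the methoxy: from compound 3 to compound 4

The source may hold more compounds than are shown below. What is called first, only, known or untested is meant among the compounds shown, and "the series" means these compounds.

Measured so far:
- compound 1, `COc1cccc(/C=C/C(=O)Nc2nc3ccccc3c(=O)s2)c1`: 205 nM
- compound 2, `O=C(CCCc1ccccc1)Nc1nc2sccc2c(=O)s1`: 35.2 nM
- compound 3, `COc1cccc(/C=C/CC(=O)Nc2nc3ccccc3c(=O)s2)c1`: 11.2 nM

Of the compounds shown here, three have been tested in an assay on membranes from brain for displacement of a labelled ligand from adenosine receptor A1 (Rattus norvegicus), read by scintillation counting, with a stated time of 90 min; a higher number here means a weaker inhibitor, a lower number a stronger inhibitor. Compound 1 gives 205 nM, compound 2 gives 35.2 nM, and compound 3 gives 11.2 nM. Compound 3 thus has the lowest number of the three in this assay; compound 2 is its nearest neighbour and compound 1 the furthest, both gaps lying beyond the scatter, so compound 3 is the strongest inhibitor of this set.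

Compound 4, `O=C(C/C=C/c1ccccc1)Nc1nc2ccccc2c(=O)s1`, has not yet been measured. It differs from compound 3 in one place: hydrogen in place of methoxy on an aromatic carbon, on a six-membered aromatic ring of carbon only, meta to a large group. Among the compounds with values here, no measured pair shows this exact change. Compound 2, which carries an unsubstituted phenyl but on a different chain and core, gives 35.2 nM, so a phenyl without the methoxy is compatible with strong inhibition, though compound 2 offers no clean comparison.

The writer expects the change to cost little, a step from compound 3 to compound 4 of a 1.8-fold higher number from compound 3 to compound 4 (0.25 log units; within the scatter), perhaps within the scatter or slightly beyond it towards a weaker inhibitor. Compound 4 is therefore estimated at 20 nM, with a likely range from 6 nM to 70 nM.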

Compound 4, inhibition constant: 53 nM
The estimate for compound 4 lay 2.7-fold (0.42 log units) below the measured number, and the stated range covers the measured number.
By their numbers in this assay, from the lowest: compound 3; then compounds 2 and 4 (each within the scatter of the next); then compound 1.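

In this assay, within the data shown here, 3-methoxyphenyl to phenyl gives a 4.7-fold higher number from compound 3 to compound 4 (0.68 log units; beyond the scatter) and so provides the first comparison that differs in one place. It shows that the methoxy on this aromatic ring is not interchangeable with hydrogen for the number read here, and that compound 3 owes part of its standing to that group, not only to its chain and core. No measurement shown here accounts for this step.

From the compounds shown here alone, whether a hydroxyl group, a chlorine or an ethoxy group in the same place would match the methoxy of compound 3 remains open. Going by these compounds, it is also open whether the loss of a methoxy would carry the same weight on the shorter chain of compound 1, or whether adding one to the phenyl of compound 2 would lower its number.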